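Swapping tert-butyl for methoxy: an expected small shift

The compounds below may be only part of what the source reports. "The series", "measured", "known", "first", "only" and "open" are said of these compounds alone.

compound 1 `COc1ccc(C(C)=O)cc1COc1ccc(Cl)cc1` gives 1200 nM
compound 2 `COc1ccc(C(N)=O)cc1/C=C\c1ccc(Cl)cc1` gives 2900 nM
compound 3 `COc1ccc(C(N)=O)cc1/C=C/c1ccc(C(C)(C)C)cc1` gives 370 nM

All three were tested in a functional assay on HUVEC cells (Homo sapiens) for inhibition, with a stated time of 4 days (on this read-out lower numbers stand for stronger inhibition and higher numbers for weaker inhibition), and compound 3, at 370 nM, has the lowest number of the set, with both other compounds higher by more than the usual scatter. The next compound to be tested is compound 4 `COc1ccc(/C=C/c2cc(C(N)=O)ccc2OC)cc1`, which keeps the rest of compound 3 and carries methoxy in place of tert-butyl on an aromatic carbon, para to a large group: methoxy in place of tert-butyl on an aromatic carbon. Among the compounds with values here, no pair of measured compounds differs in one place only, so the data offer no direct guide to the size of this change. Within the data shown here, the only close reference is compound 3 at 370 nM, so a modest rise in the number is expected in this assay, possibly not beyond the scatter. The estimated change, a 1.4-fold higher number from compound 3 to compound 4 (0.13 log units; within the scatter), carries wide uncertainty. For compound 4 the expected value is 500 nM, with an estimated range from 120 nM to 2500 nM.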

Compound 4, half-maximal inhibitory concentration: 8800 nM
For compound 4 the middle estimate is 18-fold (1.25 log units) below the measured one; the measured number lies above the stated range.
By their numbers in this assay, from the lowest: compound 3; then compound 1; then compound 2; then compound 4.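

In this assay the exchange of tert-butyl for methoxy on an aromatic carbon, para to a large group, proves to be no minor swap: it gives a 24-fold higher number from compound 3 to compound 4 (1.38 log units; beyond the scatter). Within the data shown here, this is the first direct comparison at this position, and it shows that, with the rest of compound 3 kept, the group at this one place can strongly change the read-out. Nothing measured here accounts for the size of this step.

Among these compounds, with only two groups compared in one-place steps, it remains open whether the loss comes from removing tert-butyl or from introducing methoxy. Isopropyl, trifluoromethyl or a plain hydrogen at this place, on the otherwise unchanged compound 3, would show how the read-out follows the group there.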